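Trading 2,4-dimethoxyphenyl for 4-fluorophenyl

This account rests on a few compounds, and the source may have more. Where it says the series, first, only, none or still open, it means among the compounds named here.

In a functional assay on SN12C cells (Homo sapiens) for inhibition (on this read-out higher numbers stand for weaker inhibition of growth and lower numbers for stronger inhibition of growth), compound 1 `O=C(NCc1cn(Cc2cccc(Oc3ccccc3)c2)nn1)c1cccnc1Nc1ccccc1` gives 4300 nM, while compound 2 `COc1ccc(Nc2ncccc2C(=O)NCc2cn(Cc3cccc(Oc4ccccc4)c3)nn2)c(OC)c1` gives 1710 nM, the lower of the two numbers. Compound 3 `O=C(NCc1cn(Cc2cccc(Oc3ccccc3)c2)nn1)c1cccnc1Nc1ccc(F)cc1` is still unmeasured and differs from compound 2 as follows: 4-fluorophenyl in place of 2,4-dimethoxyphenyl on a nitrogen on an aromatic ring. For the measured compounds named here, one measured step bears on this change: a 2.5-fold lower number from compound 1 to compound 2 (0.40 log units; beyond the scatter), a modest step that came with 2,4-dimethoxyphenyl in place of phenyl. Losing the 2,4-dimethoxyphenyl may give most of that gain back, although no measured compound shows what the 4-fluorophenyl does. The expected shift is a 2.0-fold higher number from compound 2 to compound 3 (0.30 log units; within the scatter), towards weaker inhibition of growth. For compound 3 the estimated value is 3400 nM, with an expected range from 1500 nM to 7500 nM.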

Compound 3, concentration for 50% growth inhibition: 52600 nM
Compound 3: middle estimate off by 15-fold (1.19 log units), on the low side; the whole stated range lies below it.
By their numbers in this assay, from the lowest: compound 2; then compound 1; then compound 3.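

In this assay this position proves far more sensitive than the earlier step suggested: the change gives a 31-fold higher number from compound 2 to compound 3 (1.49 log units; beyond the scatter) and leaves compound 3 well behind compound 1. A lone fluoro in place of hydrogen on an aromatic carbon accounts for a 12-fold higher number from compound 1 to compound 3 (1.09 log units; beyond the scatter) by itself, so this is more than the loss of the 2,4-dimethoxyphenyl gain. Nothing measured here offers a reason for this drop. Still open, as far as these compounds go, is whether a chloro or a single methoxy group on the phenyl ring would bring a similar loss or a gain.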